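Relocating the trifluoromethyl group on the phenyl substituent

A few compounds are considered here, and "the series" means these few. Any claim that something is new, unique, unknown or untested is made for them only; others in the source may bear on it.

Measured in a functional assay on T47D cells (Homo sapiens) for inhibition; a lower number here means a stronger inhibitor, a higher number a weaker inhibitor:
compound 1 `Oc1cccc(-c2cc(-c3ccccc3F)cc(-c3cccc(O)c3)n2)c1`, 4370 nM
compound 2 `Oc1cccc(-c2cc(-c3ccc(F)cc3)cc(-c3cccc(O)c3)n2)c1`, 6870 nM
compound 3 `Oc1cccc(-c2cc(-c3ccccc3C(F)(F)F)cc(-c3cccc(O)c3)n2)c1`, 4350 nM

Compound 3 holds the lowest of the three numbers, yet a 1.0-fold lower number from compound 1 to compound 3 (0.00 log units; within the scatter) and a 1.6-fold lower number from compound 2 to compound 3 (0.20 log units; within the scatter) place it within the scatter of both others, so no ordering is claimed. Compound 4 `Oc1cccc(-c2cc(-c3ccc(C(F)(F)F)cc3)cc(-c3cccc(O)c3)n2)c1` differs from compound 3 by 4-(trifluoromethyl)phenyl in place of 2-(trifluoromethyl)phenyl on an aromatic carbon. Among the compounds with values here, the one measured step that bears on this is a 1.6-fold higher number from compound 1 to compound 2 (0.20 log units; within the scatter), the same relocation with fluoro in place of trifluoromethyl, which stayed within the scatter. On that basis the step in this assay from compound 3 to compound 4 is expected to be small, if anything a slightly higher number, as a 1.4-fold higher number from compound 3 to compound 4 (0.14 log units; within the scatter). Compound 4 is therefore estimated at 6000 nM, with a range of 2500 nM to 15000 nM.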

Compound 4, half-maximal inhibitory concentration: 2330 nM
Beside the measured number, compound 4's estimate is 2.6-fold (0.41 log units) above it; measured number outside the range, below it.
By their numbers in this assay, from the lowest: compounds 4, 3, 1 and 2 (each within the scatter of the next, the first and the last beyond it).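

In this assay, moving the trifluoromethyl group gives a step that stays within the scatter, a 1.9-fold lower number from compound 3 to compound 4 (0.27 log units; within the scatter), and the same holds for exchanging 2-fluorophenyl for 4-(trifluoromethyl)phenyl, a 1.9-fold lower number from compound 1 to compound 4 (0.27 log units; within the scatter). Within the data shown here, the first step beyond the scatter is modest and comes with trifluoromethyl in place of fluoro on the 4-substituted phenyl, a 2.9-fold lower number from compound 2 to compound 4 (0.47 log units; beyond the scatter). That exchange therefore reads differently on the two phenyl patterns: the same change on two cores in this assay, a 1.0-fold lower number (0.00 log units; within the scatter) from compound 1 to compound 3 and a 2.9-fold lower number (0.47 log units; beyond the scatter) from compound 2 to compound 4, 2.9-fold (0.47 log units) apart, beyond the scatter of two such steps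

Open, as far as these compounds go, is whether an amine or a carboxylic acid in place of trifluoromethyl on the 4-substituted phenyl would follow the same trend.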